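This account rests on a few compounds, and the source may have more. Where it says the series, first, only, none or still open, it means among the compounds named here.

Compound 1 `Cc1ccncc1-c1ccc2[nH]c(=O)nc(-c3ccccc3)c2c1` was tested in an ADME assay on THP-1 cells (Homo sapiens) for cytotoxicity, read by MTT assay, with a stated time of 72 h (a lower number here means that less compound is needed, a higher number that more compound is needed for the effect), where compound 1 gives > 50000 nM, which is a limit of the assay rather than a measured number. Two relatives share its core. In this assay compound 2 `O=c1nc(-c2ccccc2)c2cc(-c3cnc4ccccc4c3)ccc2[nH]1` also gives only the limit > 50000 nM. In this assay compound 3 `N#Cc1ccc(-c2ccc3[nH]c(=O)nc(-c4ccccc4)c3c2)cc1` likewise gives the limit > 50000 nM. Going by the values given here, every value so far therefore sits at the limit of > 50000 nM in this assay, at which 3 of the 3 values shown sit, and compound 1 stands exactly where the others stand. Compound 4 `Cn1cc(-c2ccc3[nH]c(=O)nc(-c4ccccc4)c3c2)cn1` differs from compound 1 in one place: 1-methyl-1H-pyrazol-4-yl in place of 4-methylpyridin-3-yl on an aromatic carbon. Among the compounds with values here, the only measured step on this core, a step that the two limits leave unreadable from compound 1 to compound 3, runs between two limits and gives no size or direction. With no readable guide, compound 4 is expected to remain at the limit, estimated at 80000 nM, between 40000 nM and 200000 nM. The expected step that the limit leaves unreadable from compound 1 to compound 4 is thus none beyond the scatter.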

Compound 4, half-maximal effective concentration: > 50000 nM
Compound 4: only a limit was reported (the forecaster's own chance of this, stated with the estimate: 85%); the middle value lies beyond the limit too.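

Compound 4, like compound 1 and compound 3, gives only a limit in this assay, so neither step to compound 4 can be read: the limit of > 50000 nM in this assay, at which 4 of the 4 values shown sit.

The compounds shown leave open whether swapping these groups on the shared core changes the value at all, and in which direction.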